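A few compounds are considered here, and "the series" means these few. Any claim that something is new, unique, unknown or untested is made for them only; others in the source may bear on it.

Four compounds share one core, each carrying an amide-linked chain that ends in a saturated ring. Compound 1 `Cc1cc(C)c(-c2nc(CN3CCC(C(=O)NCCCN4C[C@H](C)C[C@H](C)C4)CC3)c(C)o2)c(C)c1` and compound 3 `Cc1oc(-c2c(Cl)cccc2Br)nc1CN1CCC(C(=O)NCCCN2C[C@H](C)C[C@H](C)C2)CC1` were both made, but in a physicochemical assay for permeability, using PAMPA (on this read-out higher numbers stand for higher permeability and lower numbers for lower permeability), compound 1 shows only "not determined" (no result reported) and compound 3 likewise shows "not determined" (no result reported). Among the measured compounds shown here, compound 2 `Cc1ccccc1-c1nc(CN2CCC(C(=O)NCCCN3CCC(C(C)C)CC3)CC2)c(C)o1` is therefore the single anchor: in this assay compound 2 gives 396 10^-6 cm/s, the only number in the set, so it cannot be placed above or below the other two. Compound 4 `Cc1ccccc1-c1nc(CN2CCC(C(=O)NCCN3C[C@H](C)C[C@H](C)C3)CC2)c(C)o1` is still to be measured. It differs from compound 2 at one place: 3,5-dimethylpiperidin-1-yl in place of (4-isopropylpiperidin-1-yl)methyl on a saturated chain carbon, two bonds along the chain from an amide-type nitrogen. For the measured compounds named here, no pair of measured compounds shows what a change of this kind does, so the expectation rests on compound 2 alone. The expected step is small, downward if anything, and not beyond the usual scatter: a 1.3-fold lower number from compound 2 to compound 4 (0.12 log units; within the scatter). In this assay compound 4 is accordingly estimated at 300 10^-6 cm/s, with an expected range from 150 10^-6 cm/s to 500 10^-6 cm/s.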

Compound 4, apparent permeability: 712 10^-6 cm/s
Beside the measured number, compound 4's estimate is 2.4-fold (0.38 log units) below it; the measured number lies above the stated range.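

Among the compounds shown here, this is the first measured step at this position: in this assay, 3,5-dimethylpiperidin-1-yl in place of (4-isopropylpiperidin-1-yl)methyl gives a 1.8-fold higher number from compound 2 to compound 4 (0.25 log units; within the scatter). The two compounds therefore cannot be told apart on this read-out, even though the group that enters has fewer heavy atoms than the group that leaves and brings 2 defined stereocentres. No supporting measurement bears on the reason for this result.

Cut one bond further out, the same difference reads 2-(4-isopropylpiperidin-1-yl)ethyl to (3,5-dimethylpiperidin-1-yl)methyl, so this one pair cannot separate the change in ring substituents from the change in chain length. On these data alone, compounds 1 and 3 offer no number for comparison, and it remains open how an open-chain diethylamino group or a morpholine ring would read at this place.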